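Benzyl para substituent swap in the triazole ether series

The source may hold more compounds than are shown below. What is called first, only, known or untested is meant among the compounds shown, and "the series" means these compounds.

Two compounds carry the shared core with a benzyl group on the triazole nitrogen. Compound 1 `Cc1cccc(Cn2cc(COc3ccc4c(=O)ccoc4c3)nn2)c1` gives 16000 nM in a functional assay on MDA-MB-231 cells (Homo sapiens) for cytotoxicity, read by MTT assay, with a stated time of 48 h; a higher number here means a weaker inhibitor, a lower number a stronger inhibitor. Compound 2 `O=c1ccoc2cc(OCc3cn(Cc4ccc(Br)cc4)nn3)ccc12` reaches only a limit in this assay, > 100000 nM. The step of an at least 6.2-fold higher number from compound 1 to compound 2 (0.79 log units; beyond the scatter) is therefore open at its upper side, which follows from the limit of > 100000 nM in this assay, at which 1 of the 2 values shown sits. Compound 2 thus stands at the weak end of the numbers shown, with no measured value of its own.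

Compound 3 `O=c1ccoc2cc(OCc3cn(Cc4ccc([N+](=O)[O-])cc4)nn3)ccc12` differs from compound 2 by nitro in place of bromo on an aromatic carbon. Among the measured compounds shown here, no measured step swaps one substituent for another on this benzyl ring; the only step, an at least 6.2-fold higher number from compound 1 to compound 2 (0.79 log units; beyond the scatter), changes the whole aryl group and itself ends in a limit, so its size is a floor rather than a number. The direction of the change from compound 2 to compound 3 in this assay cannot be read from the steps, and the starting point is already a limit. Compound 3 is therefore expected to sit near or beyond that limit as well, with the step of a number no higher from compound 2 to compound 3 (the limit leaves the size open) expected to stay small in either direction. The estimate for compound 3 in this assay is 100000 nM, with a range from 25000 nM to 400000 nM, and a limit is the more likely outcome.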

Compound 3, half-maximal inhibitory concentration: 71300 nM
For compound 3 the middle estimate is 1.4-fold (0.15 log units) above the measured one; measured number inside the range.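

Compound 3 gives this series its first measured number for a change away from the 3-methylphenyl group in this assay, so that change now has a size rather than only a floor: a 4.5-fold higher number from compound 1 to compound 3 (0.65 log units; beyond the scatter). The swap of bromo for nitro reads an at least 1.4-fold lower number from compound 2 to compound 3 (0.14 log units; that floor lies within the scatter), so no order can be set between these two groups on the benzyl ring. Going by these compounds, the size of that step stays open because of a limit, which belongs to compound 2: the limit of > 100000 nM in this assay, at which 1 of the 3 values shown sits.

Whether the higher numbers of compound 2 and compound 3 go with the kind of substituent or with its place on the ring stays open, as no pair shown changes the place while keeping the substituent. Also open, on these data alone, is how an amine or a carboxylic acid on this ring, or a longer chain on the triazole nitrogen in place of the benzyl group, would read in this assay.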